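Amide substituent exchange in a piperidine pyridine N-oxide series

The compounds below may be only part of what the source reports. "The series", "measured", "known", "first", "only" and "open" are said of these compounds alone.

Measured compounds:
compound 1 `Cc1cccc(C(=O)NCN2CCC(c3ccccn3)CC2)c1`: 9 nM
compound 2 `Cc1cc(NC(=O)CN2CCC(c3cccc[n+]3[O-])CC2)ccc1F`: 18 nM
compound 3 `O=C(NCN1CCC(c2cccc[n+]2[O-])CC1)c1cc(Cl)cc(Cl)c1`: 45 nM

Compound 2 stands second highest of the three numbers in a functional assay on HEK293 cells for agonist activity at D(4) dopamine receptor (Homo sapiens), read by FLIPR; a higher number here means that more compound is needed for the effect, a lower number that less compound is needed. Its nearest neighbour is compound 1, within the scatter; compound 3 lies beyond the scatter with a higher number. Compound 4 `O=C(CN1CCC(c2cccc[n+]2[O-])CC1)NC1CCCCC1` differs from compound 2 by cyclohexyl in place of 4-fluoro-3-methylphenyl on an amide-type nitrogen. Within the data shown here, no measured pair shows this change, so its size is open. With 4-fluoro-3-methylphenyl leaving and cyclohexyl entering on the amide-type nitrogen, a move to a higher number in this assay is expected, probably beyond the scatter. Compound 4 is estimated at 60 nM, range 15 nM to 250 nM. For compound 4 this means an expected step of a 3.3-fold higher number from compound 2 to compound 4 (0.52 log units; beyond the scatter).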

Compound 4, half-maximal effective concentration: 294 nM
For compound 4 the middle estimate is 4.9-fold (0.69 log units) below the measured one; the whole stated range lies below it.
By their numbers in this assay, from the lowest: compounds 1 and 2 (each within the scatter of the next); then compound 3; then compound 4.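

Replacing 4-fluoro-3-methylphenyl with cyclohexyl on the amide-type nitrogen gives a 16-fold higher number from compound 2 to compound 4 (1.21 log units; beyond the scatter) in this assay, so this position does not treat the two six-membered rings as interchangeable. Among these compounds, this is the only single-place step, and it is large. Nothing measured here bears on the reason for it.

The step changes ring type and removes the fluorine and methyl together, so their shares remain unresolved. Going by these compounds, whether unsubstituted phenyl would sit nearer compound 2 or compound 4 remains open, as does the outcome with an open-chain group such as isopropyl.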